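Aryl urea series: exchange of bromo for iodo

The compounds below may be only part of what the source reports. "The series", "measured", "known", "first", "only" and "open" are said of these compounds alone.

Compound 3 `C[C@@H](NC(=O)Nc1ccc(Br)cc1)c1ccccc1` carries the highest of the three numbers in an ADME assay on the whole organism with Oryza sativa as the target, tested at 0.1 uM (on this read-out higher numbers stand for a weaker effect at the one concentration tested and lower numbers for a stronger effect), giving 100%, though every step to it lies within the scatter. Its nearest neighbour is compound 2 `C[C@@H](NC(=O)Nc1ccc(F)cc1)c1ccccc1`, which gives 98%; the furthest is compound 1 `CCc1ccc(NC(=O)N[C@H](C)c2ccccc2)cc1`, which gives 95%. The gaps are a number 2 percentage points higher from compound 2 to compound 3 (within the scatter) and a number 5 percentage points higher from compound 1 to compound 3 (within the scatter), and between the other two a number 3 percentage points higher from compound 1 to compound 2 (within the scatter). Compound 4 `C[C@@H](NC(=O)Nc1ccc(I)cc1)c1ccccc1` differs from compound 3 by iodo in place of bromo on an aromatic carbon. All three measured steps are exchanges of one group for another on an aromatic carbon, and none left the scatter, so compound 4 is expected to show only a number 1 percentage points lower from compound 3 to compound 4 (within the scatter), nothing beyond the scatter. The estimate for compound 4 is 99%, ranging from 93% to 100%.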

Compound 4, a percentage reported as activity, at one concentration (the size of the read-out at that concentration, not a potency): 100%
Compound 4: the middle estimate sits 1 percentage points below what was measured; the range from low to high includes it.
By their numbers in this assay, from the lowest: compounds 1, 2, 3 and 4 (each within the scatter of the next).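

In this assay, no change at the digits printed from compound 3 to compound 4 (within the scatter) and a number 2 percentage points higher from compound 2 to compound 4 (within the scatter) and a number 5 percentage points higher from compound 1 to compound 4 (within the scatter) are the new steps, so iodo adds a fourth group to this place without any step leaving the scatter. On an aromatic carbon para to a large group, ethyl, fluoro, bromo and iodo now all lie within the scatter of one another, and the exchange of bromo for iodo adds no exception. Nothing measured bears on why this position gives so little separation. Going by these compounds, whether an amine or a carboxylic acid at this place would give a step beyond the scatter remains open. Also open, on these data alone, is whether changes elsewhere on the shared core would move the number at all.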